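The compounds below may be only part of what the source reports. "The series", "measured", "known", "first", "only" and "open" are said of these compounds alone.

Working notes on the series. Compound 1 `O=[N+]([O-])c1ccc(-c2nnc(-c3cccnc3)n2Nc2nc3ccc(Br)cc3s2)cc1` gives 13.2 ug/mL in an ADME assay on MT4 cells (Homo sapiens) for cytotoxicity, read by MTT assay, with a stated time of 5 days; a lower number here means that less compound is tolerated, a higher number that more compound is tolerated; compound 2 `Cc1cccc2sc(Nn3c(-c4ccc([N+](=O)[O-])cc4)nnc3-c3cccnc3)nc12` gives 13.5 ug/mL; compound 3 `O=[N+]([O-])c1ccc(-c2nnc(-c3cccnc3)n2Nc2nc3c([N+](=O)[O-])cccc3s2)cc1` gives 13.8 ug/mL. Compound 3 holds the highest of the three numbers, yet both neighbours sit within the scatter of it, so no order among the three can be read. The steps seen so far, a 1.0-fold higher number from compound 1 to compound 2 (0.01 log units; within the scatter) and a 1.0-fold higher number from compound 2 to compound 3 (0.01 log units; within the scatter), both stayed within the scatter, and this assay has not moved across any change at this position. Compound 4 `O=[N+]([O-])c1ccc(-c2nnc(-c3cccnc3)n2Nc2nc3c(Cl)cccc3s2)cc1` differs from compound 3 by chloro in place of nitro on an aromatic carbon. For compound 4 the expected step is a 1.0-fold lower number from compound 3 to compound 4 (0.01 log units; within the scatter), none beyond the scatter, and for compound 4 the estimate in this assay is 13.5 ug/mL, with a range from 7 ug/mL to 27 ug/mL.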

Compound 4, half-maximal cytotoxic concentration: 15.6 ug/mL
Estimate against measurement, compound 4: 1.2-fold (0.06 log units) below; the range from low to high includes it.
By their numbers in this assay, from the lowest: compounds 1, 2, 3 and 4 (each within the scatter of the next).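

In this assay the chloro compound shows a 1.1-fold higher number from compound 3 to compound 4 (0.05 log units; within the scatter) and also a 1.2-fold higher number from compound 2 to compound 4 (0.06 log units; within the scatter) when methyl is the group replaced. Moving to 4-chloro-1,3-benzothiazol-2-yl from 6-bromo-1,3-benzothiazol-2-yl gives a 1.2-fold higher number from compound 1 to compound 4 (0.07 log units; within the scatter) and likewise stays within the scatter, so chloro joins nitro and methyl as a change that separates nothing here. No evidence bears on this flat result. As far as these compounds go, whether an amine or a carboxylic acid on this aromatic carbon would move the number remains open. Changes elsewhere on the shared core also remain open.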